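Acyl Variation at the Outer Sugar and Antiproliferative Potency

The compounds below may be only part of what the source reports. "The series", "measured", "known", "first", "only" and "open" are said of these compounds alone.

Compound 1, `CCCCCCCCO[C@@H]1O[C@@H](C)[C@H](OC(=O)CCCCC)[C@@H](O[C@@H]2O[C@@H](C)[C@H](OC(C)=O)[C@@H](O)[C@H]2OC(C)=O)[C@H]1O`: in a functional assay on NCI-H460 cells (Homo sapiens) for antiproliferative activity, read by MTT assay, with a stated time of 48 h (on this read-out lower numbers stand for stronger inhibition and higher numbers for weaker inhibition), compound 1 reaches only the limit > 500000 nM.
Compound 2, `CCCCCCCCO[C@@H]1O[C@@H](C)[C@H](OC(=O)CCCCC)[C@@H](O[C@@H]2O[C@@H](C)[C@H](OC(C)=O)[C@@H](OC(C)=O)[C@H]2OC(C)=O)[C@H]1O`: compound 2 gives 15000 nM.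
Compound 3, `CCCCCCCCO[C@@H]1O[C@@H](C)[C@H](OC(=O)CCCCC)[C@@H](O[C@@H]2O[C@@H](C)[C@H](OC(C)=O)[C@@H](OC(=O)C(C)(C)C)[C@H]2OC(C)=O)[C@H]1O`: compound 3 gives 141000 nM.

The value for compound 1 is a limit of this assay and not a number. Among the two numbers that are measured, compound 3 stands highest; its nearest neighbour is compound 2, and the step of a 9.4-fold higher number from compound 2 to compound 3 (0.97 log units; beyond the scatter) separates them. Going from compound 1 to compound 3 gives an at least 3.5-fold lower number from compound 1 to compound 3 (0.54 log units; beyond the scatter), and from compound 1 to compound 2 gives an at least 33-fold lower number from compound 1 to compound 2 (1.52 log units; beyond the scatter).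

Compound 4, `CCCCCCCCO[C@@H]1O[C@@H](C)[C@H](OC(=O)CCCCC)[C@@H](O[C@@H]2O[C@@H](C)[C@H](OC(C)=O)[C@@H](OC(=O)CCC)[C@H]2OC(C)=O)[C@H]1O`, is not yet measured. It differs from compound 3 only in that (propyl in place of tert-butyl on a carbonyl carbon). The step that bears on this change is a 9.4-fold higher number from compound 2 to compound 3 (0.97 log units; beyond the scatter), in which a larger acyl group gave the higher number; the propyl group of compound 4 lies between the methyl of compound 2 and the tert-butyl of compound 3 in size, so a move back toward the number of compound 2 is expected. The expected step is a 3.5-fold lower number from compound 3 to compound 4 (0.55 log units; beyond the scatter). Compound 4 is estimated at 40000 nM, with a range from 10000 nM to 160000 nM.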

Compound 4, half-maximal inhibitory concentration: 32000 nM
Estimate against measurement, compound 4: 1.3-fold (0.10 log units) above, and the stated range covers the measured number.
By their numbers in this assay, from the lowest: compound 2; then compound 4; then compound 3. At a limit, above all of these: compound 1.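

In this assay, exchanging tert-butyl for propyl on the carbonyl carbon gives a 4.4-fold lower number from compound 3 to compound 4 (0.64 log units; beyond the scatter) and so recovers much of the loss seen with compound 3. Although propyl has 3 heavy atoms against 4 for tert-butyl, the ester of compound 4 remains close to the acetyl ester, with a 2.1-fold higher number from compound 2 to compound 4 (0.33 log units; beyond the scatter) still beyond the scatter, so the three acyl groups now form an order with acetyl lowest and tert-butyl highest. Acylating the free hydroxyl with this group gives an at least 15-fold lower number from compound 1 to compound 4 (1.19 log units; beyond the scatter) as a bound only, since compound 1 stands at a limit: the limit of > 500000 nM in this assay, at which 1 of the 4 values shown sits.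

These compounds do not separate branching from chain length, which an isopropyl group on the same carbonyl carbon would address. On these data alone, how a longer straight chain or a benzoyl ester would read also remains open.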